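A few compounds are considered here, and "the series" means these few. Any claim that something is new, unique, unknown or untested is made for them only; others in the source may bear on it.

Compound 1 `Cc1ccccc1S(=O)(=O)Nc1ccc2oc(-c3ccccc3)nc2c1` is a sulfonamide built on a shared core. In an assay on isolated protein for inhibition of malate dehydrogenase, mitochondrial (Sus scrofa), with stated times of 45 min and 30 min (on this read-out higher numbers stand for weaker inhibition and lower numbers for stronger inhibition), compound 1 gives > 63000 nM, which is a limit of the assay rather than a measured number. Compound 2 `O=S(=O)(Nc1ccc(-c2nc3ccccc3o2)cc1)c1ccc(F)c(C(F)(F)F)c1` gives > 63000 nM in this assay, again only a limit. Compound 3 `O=[N+]([O-])c1cc(S(=O)(=O)Nc2ccc(-c3nc4ccccc4o3)cc2)ccc1Cl` gives > 63000 nM in this assay, also a limit. Compound 1 therefore stands exactly where everything shown stands, at the limit of > 63000 nM in this assay, at which 3 of the 3 values shown sit. Compound 4 `Cc1cccc(S(=O)(=O)Nc2ccc3oc(-c4ccccc4)nc3c2)c1` differs from compound 1 by a single change (3-methylphenyl in place of 2-methylphenyl on a sulfonyl sulfur). No step between measured compounds is available, and because the limit of > 63000 nM in this assay, at which 3 of the 3 values shown sit, places all three shown values at the same limit, no step beyond the scatter is expected. Compound 4 is expected to give 80000 nM, within a range from 30000 nM to 250000 nM. The expected step that the limit leaves unreadable from compound 1 to compound 4 is essentially none.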

Compound 4, half-maximal inhibitory concentration: > 63000 nM
Compound 4: only a limit was reported; the forecaster's own chance of this, stated with the estimate: 85%; the middle value lies beyond the limit too.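

Compound 1 and compound 4 both stop at a limit of the assay, so no step can be read between them: the limit of > 63000 nM in this assay, at which 4 of the 4 values shown sit. In this assay the compounds shown leave open which structural change, if any, would give a measurable value.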